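A few compounds are considered here, and "the series" means these few. Any claim that something is new, unique, unknown or untested is made for them only; others in the source may bear on it.

Three compounds have been measured in a functional assay on HOP-92 cells (Homo sapiens) for inhibition, read by sulforhodamine B assay, with a stated time of 48 h; on this read-out lower numbers stand for stronger inhibition of growth and higher numbers for weaker inhibition of growth:
compound 1 `O=C(Nc1cccc(-n2cc(-c3ccncc3)c(-c3ccc(Cl)c(O)c3)n2)c1)Nc1cccc(C(F)(F)F)c1`: 509 nM
compound 2 `COc1cc(-c2nn(-c3cccc(NC(=O)Nc4ccc(Cl)c(Cl)c4)c3)cc2-c2ccncc2)ccc1Cl`: 151 nM
compound 3 `O=C(Nc1cccc(-n2cc(-c3ccncc3)c(-c3ccc(Cl)c(O)c3)n2)c1)Nc1ccc(Cl)c(Cl)c1`: 679 nM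

Of these three, compound 2 has the lowest number, at 151 nM. Compound 4 `COc1cc(-c2nn(-c3cccc(NC(=O)c4ccc(Cl)c(C(F)(F)F)c4)c3)cc2-c2ccncc2)ccc1Cl` differs from it in one place, with 4-chloro-3-(trifluoromethyl)phenyl in place of (3,4-dichlorophenyl)amino on a carbonyl carbon.

The measured step closest in kind exchanges 3-(trifluoromethyl)phenyl for 3,4-dichlorophenyl on an amide-type nitrogen, and it is small: a 1.3-fold higher number from compound 1 to compound 3 (0.13 log units; within the scatter). The other step, a 4.5-fold higher number from compound 2 to compound 3 (0.65 log units; beyond the scatter), is larger, but it concerns hydrogen in place of methyl on an oxygen, which compound 4 does not change. Among the measured compounds shown here, no measured step removes the amino nitrogen, so that part of the change is untested and the direction stays open. In this assay, a step within the scatter is therefore expected, estimated as a 1.3-fold higher number from compound 2 to compound 4 (0.12 log units; within the scatter). For compound 4 the estimated value is 200 nM, with an expected range of 70 nM to 600 nM.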

Compound 4, concentration for 50% growth inhibition: 665 nM
The estimate for compound 4 lay 3.3-fold (0.52 log units) below the measured number; measured number above the stated range.
By their numbers in this assay, from the lowest: compound 2; then compounds 1, 4 and 3 (each within the scatter of the next).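

In this assay the change on the carbonyl carbon gives a 4.4-fold higher number from compound 2 to compound 4 (0.64 log units; beyond the scatter) and so lies beyond the scatter, whereas exchanging one aryl group for another on the amide-type nitrogen gave only a 1.3-fold higher number from compound 1 to compound 3 (0.13 log units; within the scatter) and stayed within it. The step removes (3,4-dichlorophenyl)amino, with its hydrogen-bond donor, and brings in 4-chloro-3-(trifluoromethyl)phenyl, which has none, so the loss of the nitrogen and the change of ring substituents are read together and this one step cannot separate them. Nothing available explains why the number rises. As far as these compounds go, it remains open how a morpholine or an unsubstituted phenyl on the carbonyl carbon would read. From the compounds shown here alone, it also remains open whether hydrogen in place of methyl on the oxygen would shift compound 4 as it does compound 2.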